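A few compounds are considered here, and "the series" means these few. Any claim that something is new, unique, unknown or untested is made for them only; others in the source may bear on it.

Measured so far:
compound 1, `CC(C)CCn1cnc2c(Nc3cccc(O)c3)nc(N[C@H]3CC[C@H](N)CC3)nc21` — 7600 nM
compound 2, `N[C@H]1CC[C@H](Nc2nc(Nc3ccc(O)cc3)c3ncn(C4CCCCC4)c3n2)CC1` — 8900 nM

Of the compounds shown here, two have been tested in a functional assay on K562 cells (Homo sapiens) for inhibition, read by fluorescence, with a stated time of 72 h; a lower number here means a stronger inhibitor of growth, a higher number a weaker inhibitor of growth. Compound 1 `CC(C)CCn1cnc2c(Nc3cccc(O)c3)nc(N[C@H]3CC[C@H](N)CC3)nc21` gives 7600 nM in this assay. Compound 2 `N[C@H]1CC[C@H](Nc2nc(Nc3ccc(O)cc3)c3ncn(C4CCCCC4)c3n2)CC1` gives 8900 nM, the higher of the two numbers, though its gap to compound 1 lies within the scatter, so the two read as equivalent.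

Compound 3 `CC(C)CCn1cnc2c(Nc3ccc(O)cc3)nc(N[C@H]3CC[C@H](N)CC3)nc21` is not yet measured. It differs from compound 2 in one place: isopentyl in place of cyclohexyl on an aromatic nitrogen Compound 1 already carries isopentyl on an aromatic nitrogen, and its number in this assay matches that of compound 2 within the scatter. On that basis the step from compound 2 to compound 3 is expected to be small, with no direction beyond the scatter, a 1.1-fold lower number from compound 2 to compound 3 (0.05 log units; within the scatter).

Compound 3 is therefore estimated at 8000 nM in this assay, within a range from 3500 nM to 18000 nM.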

Compound 3, concentration for 50% growth inhibition: 4600 nM
For compound 3 the middle estimate is 1.7-fold (0.24 log units) above the measured one; measured number inside the range.
By their numbers in this assay, from the lowest: compounds 3, 1 and 2 (each within the scatter of the next).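

In this assay, the change of cyclohexyl to isopentyl on the aromatic nitrogen can now be read on its own, with the rest of the molecule held the same: it gives a 1.9-fold lower number from compound 2 to compound 3 (0.29 log units; within the scatter), so a six-membered carbon ring and this open chain cannot be told apart at this position. Among these compounds, the hydroxyl position on the phenyl group can also be read on its own for the first time: with isopentyl held fixed, 4-hydroxyphenyl in place of 3-hydroxyphenyl gives a 1.7-fold lower number from compound 1 to compound 3 (0.22 log units; within the scatter), so these two placements cannot be told apart either. No independent data bear on either step.

From the compounds shown here alone, whether a methyl group, a longer chain or a chain ending in an amine on that aromatic nitrogen would move the number beyond the scatter remains open. So does the effect of a methoxy group in place of the hydroxyl on the phenyl group.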